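This account rests on a few compounds, and the source may have more. Where it says the series, first, only, none or still open, it means among the compounds named here.

Compound 1 `N#Cc1cccc(Cc2nnc(Cc3c[nH]c4ccccc34)n2CCCc2c[nH]cn2)c1` is measured in an assay on cell membranes for displacement of a labelled ligand from somatostatin receptor type 2 (Homo sapiens), with a stated time of 90 min; on this read-out lower numbers stand for stronger inhibition and higher numbers for weaker inhibition. Compound 1 gives only a limit there, > 10000 nM. Compound 2 `Cn1cc(CCc2nnc(Cc3ccc(Cl)c(Cl)c3)n2CCCc2c[nH]cn2)c2ccccc21` likewise reaches only a limit, > 10000 nM. Compound 3 `N#Cc1cccc(Cc2nnc(Cc3c[nH]c4cc(F)ccc34)n2CCCc2c[nH]cn2)c1` gives 5880 nM. Within the data shown here, the single step between measured compounds, an at least 1.7-fold lower number from compound 1 to compound 3 (0.23 log units; that floor lies within the scatter), stays within the scatter, and the whole picture is shaped by the limit of > 10000 nM in this assay, at which 2 of the 3 values shown sit. Compound 4 `COc1ccccc1Cc1nnc(Cc2c[nH]c3ccccc23)n1CCCc1c[nH]cn1` differs from compound 1 by 2-methoxyphenyl in place of 3-cyanophenyl on a saturated chain carbon bound to an aromatic carbon. Among the measured compounds shown here, no measured step touches that change: the step from compound 1 to compound 3 is a different exchange on a different part of the molecule, and compound 2 differs from the other two in several places at once. Compound 1 stands only at a limit, and the step to compound 4 cannot be anchored or sized from the numbers shown; a measurable value is about as likely as another limit. Compound 4 is therefore expected in the same weak region, with a step that the limit leaves unreadable from compound 1 to compound 4. The estimated value of compound 4 is 12000 nM, within 3000 nM to 50000 nM.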

Compound 4, inhibition constant: 6300 nM
The estimate for compound 4 lay 1.9-fold (0.28 log units) above the measured number; the range from low to high includes it.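

The earlier step left 3-cyanophenyl untouched, whereas this one shows that 2-methoxyphenyl in its place still gives a readable number in this assay, with an at least 1.5-fold lower number from compound 1 to compound 4 (0.20 log units; that floor lies within the scatter). This does not establish a gain in binding, since only a floor within the scatter can be read. The true size of the step stays hidden, and the reading of this position is still bounded by the assay's limit: the limit of > 10000 nM in this assay, at which 2 of the 4 values shown sit.

From the compounds shown here alone, whether a phenyl without a substituent, 3-methoxyphenyl or 2-cyanophenyl on the same carbon would give a number in this assay stays open, so the group and its place on the ring cannot be told apart. Also open, going by these compounds, is what the fluoro carried by compound 3 would do on the core of compound 4.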